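The source may report more compounds than this note shows. Statements on the series, on what has been measured and on what is new or still open speak of the compounds shown alone.

Working notes on the series. In a functional assay on BGC-823 cells (Homo sapiens) for cytotoxicity, read by CCK-8 assay, with a stated time of 24 h (on this read-out lower numbers stand for stronger inhibition and higher numbers for weaker inhibition), compound 1 `C/C(=C\c1cc(-c2ccc(F)cc2)cs1)C(N)=O` gives only a limit, > 50000 nM. In this assay compound 2 `C/C(=C\c1cc(-c2ccc(C#N)cc2)cs1)C(N)=O` likewise gives only a limit, > 50000 nM. In this assay compound 3 `C/C(=C\c1cc(-c2ccc([N+](=O)[O-])cc2)cs1)C(N)=O` also gives only a limit, > 50000 nM. All three values sit at the limit of > 50000 nM in this assay, at which 3 of the 3 values shown sit, so compound 3 stands at the limit together with the other two, with no number that would set it apart from them. The measured steps are a step that the two limits leave unreadable from compound 1 to compound 2, a step that the two limits leave unreadable from compound 1 to compound 3 and a step that the two limits leave unreadable from compound 2 to compound 3; none of them can be read, as limits stand at both ends of each. Compound 4 `COc1ccc(-c2csc(/C=C(\C)C(N)=O)c2)cc1` differs from compound 3 by methoxy in place of nitro on an aromatic carbon. These three unreadable steps are the only ones that bear on this change, and each of them shows a substituent swap on the same aromatic carbon that left the value at the limit. For compound 4 the expected step in this assay is a step that the limit leaves unreadable from compound 3 to compound 4, with the value most likely again reported only as a limit. Compound 4 is estimated at 60000 nM, within a range of 20000 nM to 200000 nM.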

Compound 4, half-maximal inhibitory concentration: > 50000 nM
Compound 4: no number, only a limit; the forecaster's own chance of this, stated with the estimate: 80%; the middle value does not contradict the limit.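

No new step can be read: compound 4 gives only a limit, as do compound 1, compound 2 and compound 3, so limits stand at both ends of its steps to them: the limit of > 50000 nM in this assay, at which 4 of the 4 values shown sit.

The compounds shown leave open how these four compare in this assay, and whether any substituent at this place gives a measurable value.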